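The source may report more compounds than this note shows. Statements on the series, on what has been measured and on what is new or still open speak of the compounds shown alone.

Compound 1 `CN1C[C@@H]2C[C@H]1CN2c1ccc(-c2ccnc3c(-c4cccc5[nH]ncc45)c(-c4ccncc4)nn23)cc1` is the reference point of this small set. In a functional assay on A-375 cells (Homo sapiens) for inhibition, read by MTT assay, with a stated time of 4 days (on this read-out higher numbers stand for weaker inhibition and lower numbers for stronger inhibition), compound 1 gives 202 nM. Compound 2 `CN1C[C@@H]2C[C@H]1CN2c1ccc(-c2ccnc3c(-c4ccc(F)c5[nH]ncc45)c(-c4ccncc4)nn23)cc1` differs from it by fluoro in place of hydrogen on an aromatic carbon; in this assay compound 2 gives 68 nM, and the step is a 3.0-fold lower number from compound 1 to compound 2 (0.47 log units; beyond the scatter). Compound 3 `c1cc(-c2c(-c3ccncc3)nn3c(-c4ccc(CN5C[C@@H]6C[C@H]5CO6)cc4)ccnc23)c2cn[nH]c2c1` carries a different group on the phenyl ring: a group of 8 heavy atoms (6 carbon, 1 nitrogen, 1 oxygen; 2 five-membered non-aromatic rings with 1 hetero atom each) in place of a group of 8 heavy atoms (6 carbon, 2 nitrogen; 2 five-membered non-aromatic rings with 1 hetero atom each), on an aromatic carbon. In this assay compound 3 gives 945 nM, which is a 4.7-fold higher number from compound 1 to compound 3 (0.67 log units; beyond the scatter). Compound 3 thus stands at the highest number of the three measured, with compound 2 the furthest away from it.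

Compound 4 `Fc1cc(CN2C[C@@H]3C[C@H]2CO3)ccc1-c1ccnc2c(-c3cccc4[nH]ncc34)c(-c3ccncc3)nn12` has not yet been measured. It differs from compound 3 by fluoro in place of hydrogen on an aromatic carbon. This is the same kind of change as that made from compound 1 to compound 2, but not the same: in compound 2 the fluoro sits on a carbon that is part of a fused or bridged system of two rings, ortho to a fused ring, meta to a fused ring and para to a large group, whereas in compound 4 it sits on a ring of carbon only that is not fused, ortho to a large group and meta to a group of 8 heavy atoms. Among the measured compounds shown here, the single earlier fluoro step was a 3.0-fold lower number from compound 1 to compound 2 (0.47 log units; beyond the scatter), and it is the only guide available; the new position has no measured counterpart, so the outcome there is less certain. The step from compound 3 is expected to be smaller, a 1.6-fold lower number from compound 3 to compound 4 (0.20 log units; within the scatter). On that basis compound 4 is estimated to give 600 nM in this assay, with a range from 250 nM to 1500 nM.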

Compound 4, half-maximal inhibitory concentration: 268 nM
Estimate against measurement, compound 4: 2.2-fold (0.35 log units) above; the measured number falls inside the stated range.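

In this assay, fluoro in place of hydrogen on an aromatic carbon of the core of compound 3 gives a 3.5-fold lower number from compound 3 to compound 4 (0.55 log units; beyond the scatter), and set beside the earlier fluoro step it agrees in direction and in size: the same change on two cores in this assay, a 3.0-fold lower number (0.47 log units; beyond the scatter) from compound 1 to compound 2 and a 3.5-fold lower number (0.55 log units; beyond the scatter) from compound 3 to compound 4, 1.2-fold (0.07 log units) apart, within the scatter of two such steps. Within these two pairs, then, the change lowers the number by a like amount on both cores, and neither pair goes against this, so the earlier step was a fair guide to the later one even though the two cores carry different groups of 8 heavy atoms. This does not amount to a rule, since it rests on two pairs only and the fluoro does not sit at the same place in them: in compound 4 it stands on a six-membered aromatic ring of carbon only, ortho to a large group, and in compound 2 it stands elsewhere, so the match cannot separate what belongs to the core from what belongs to the place.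

The compounds shown leave open whether each fluoro position would give the same step on the other core, and whether the two positions would add up when carried together on one core. They also leave open whether a chloro or a methoxy group on the same aromatic carbon would lower the number as fluoro does.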